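Shortening the Chain of Compound 2

A few compounds are considered here, and "the series" means these few. Any claim that something is new, unique, unknown or untested is made for them only; others in the source may bear on it.

Measured in a functional assay on A549 cells (Homo sapiens) for inhibition, read by MTT assay, with a stated time of 72 h; a lower number here means a stronger inhibitor, a higher number a weaker inhibitor:
- Compound 1 `CNC(=O)CCCCCCCn1nc(-c2cnc3[nH]ccc3c2)c2c(N)ncnc21`: 51000 nM
- Compound 2 `Nc1ncnc2c1c(-c1cnc3[nH]ccc3c1)nn2CCCCCCCCC(=O)NO`: 12300 nM

Compound 2 holds the lower of the two numbers at 12300 nM, and it is the stronger inhibitor of the pair. Compound 3 `Nc1ncnc2c1c(-c1cnc3[nH]ccc3c1)nn2CCCCCC(=O)NO` has not been measured. It has hydroxycarbamoyl in place of 3-(hydroxycarbamoyl)propyl on a saturated chain carbon, five bonds along the chain from an aromatic nitrogen. Among the measured compounds shown here, the only measured step is a 4.1-fold lower number from compound 1 to compound 2 (0.62 log units; beyond the scatter). It puts (hydroxycarbamoyl)methyl in place of methylcarbamoyl, so it does not isolate the change at hand. For the measured compounds named here, no measured pair shows the hydroxycarbamoyl kept while the chain shortens, and the data therefore give no firm direction. The expected step is small, within the scatter: a 1.2-fold higher number from compound 2 to compound 3 (0.09 log units; within the scatter). Compound 3 is estimated at 15000 nM, with an expected range of 5000 nM to 45000 nM.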

Compound 3, half-maximal inhibitory concentration: > 150000 nM
Compound 3 ended at the assay's limit (the forecaster's own chance of this, stated with the estimate: 10%); at least 10-fold (1.00 log units) between middle value and limit.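

Compound 3 gives > 150000 nM in this assay, and this is a limit of the assay, not a number: the limit of > 150000 nM in this assay, at which 1 of the 3 values shown sits. With hydroxycarbamoyl kept at the chain end, shortening the chain alone gives an at least 12-fold higher number from compound 2 to compound 3 (1.08 log units; beyond the scatter), so chain length at this position bears strongly on the read-out, which the earlier pair, differing only in the end group, could not show. The gain seen with hydroxycarbamoyl on the longer chain does not carry over, since the change to the shorter hydroxycarbamoyl chain gives an at least 2.9-fold higher number from compound 1 to compound 3 (0.46 log units; beyond the scatter), with methylcarbamoyl on the longer chain keeping the lower number.

Going by these compounds, how far compound 3 lies beyond the limit stays open, as does the course of the number over chains of intermediate length. On these data alone, whether a longer chain than that of compound 2, or a carboxylic acid at the chain end, would lower the number also stays open.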